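Methyl to Ethyl Extension on a Shared Core

The source may report more compounds than this note shows. Statements on the series, on what has been measured and on what is new or still open speak of the compounds shown alone.

Three compounds sharing one core were tested in a functional assay on the whole organism (Abdomen) with Mus musculus as the target; a higher number here means that more compound is needed for the effect, a lower number that less compound is needed. Compound 1 `CCc1nc(Cc2c[nH]cn2)c(CC)s1` gives 1.8 mg/kg in this assay, compound 2 `CCc1sc(C)nc1Cc1c[nH]cn1` gives 2.3 mg/kg, and compound 3 `Cc1nc(Cc2c[nH]cn2)sc1C` gives 1.7 mg/kg. Compound 4 `CCc1nc(Cc2c[nH]cn2)sc1C` awaits measurement in this assay. Compound 4 differs from compound 3 by methyl in place of hydrogen on a saturated chain carbon bound to an aromatic carbon. The same change separates compound 2 from compound 1, namely (methyl in place of hydrogen on a saturated chain carbon bound to an aromatic carbon), and it occurs twice among these compounds. How the core of compound 2 differs from that of compound 3 is not broken down here. For the measured pair the change gave a 1.3-fold lower number from compound 2 to compound 1 (0.11 log units; within the scatter). Because a 1.3-fold lower number from compound 2 to compound 1 (0.11 log units; within the scatter) lies within the scatter, a similarly small step is expected, a 1.1-fold lower number from compound 3 to compound 4 (0.05 log units; within the scatter). Compound 4 is therefore estimated at 1.5 mg/kg, most likely between 0.8 mg/kg and 2.8 mg/kg.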

Compound 4, dose for half-maximal effect: > 30 mg/kg
Compound 4 ended at the assay's limit; the forecaster's own chance of this, stated with the estimate: 0%; at least 20-fold (1.30 log units) between middle value and limit.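

In this assay, the methyl to ethyl change gave an at least 17-fold higher number from compound 3 to compound 4 (1.24 log units; beyond the scatter), so the small step seen on the other core did not carry over: the same change on two cores in this assay, a 1.3-fold lower number (0.11 log units; within the scatter) from compound 2 to compound 1 and an at least 17-fold higher number (1.24 log units; beyond the scatter) from compound 3 to compound 4, at least 22-fold (1.35 log units) apart, beyond the scatter of two such steps

As far as these compounds go, compound 4 stands at > 30 mg/kg, which is a limit of the assay and not a number, so the full size of this step stays unknown. With a single pair on each core, this shows that the change cannot be assumed to transfer between these cores, but not which difference between the cores is responsible.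

The compounds shown leave open how a propyl chain or an amine on the same saturated chain carbon would read on either core. They also leave open whether other changes would diverge between these cores in the same way.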